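The source may report more compounds than this note shows. Statements on the series, on what has been measured and on what is new or still open speak of the compounds shown alone.

Series notes. Compound 1 `O=C(CC(CC(=O)NC1Cc2ccccc2C1)c1ccc(Cl)cc1)NCCN1CCCCC1` carries a chloro on the aromatic carbon of the pendant six-membered ring; in a functional assay on HeLa cells (Homo sapiens) for inhibition (a lower number here means a stronger inhibitor, a higher number a weaker inhibitor), compound 1 gives 86200 nM. Compound 2 `O=C(CC(CC(=O)NC1Cc2ccccc2C1)c1ccccc1)NCCN1CCCCC1` has hydrogen in place of that chloro. In this assay compound 2 gives only a limit, > 100000 nM, not a number. The step of an at least 1.1-fold higher number from compound 1 to compound 2 (0.06 log units; that floor lies within the scatter) therefore carries little weight, since the floor of that step sits within the scatter and the end point is the limit of > 100000 nM in this assay, at which 1 of the 2 values shown sits.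

Compound 3 `Cc1ccc(C(CC(=O)NCCN2CCCCC2)CC(=O)NC2Cc3ccccc3C2)cc1` is the next step from compound 2: methyl in place of hydrogen on an aromatic carbon. Within the data shown here, the only measured step that bears on this position is an at least 1.1-fold higher number from compound 1 to compound 2 (0.06 log units; that floor lies within the scatter), and it shows that a substituent on this aromatic carbon changes the number by little, if at all, so a methyl there is not expected to move compound 3 beyond the scatter either; the step is estimated as a number no higher from compound 2 to compound 3 (the limit leaves the size open). Compound 3 is thus expected to sit near the upper edge of what this assay resolves, at 100000 nM, with a range from 50000 nM to 300000 nM, and a real chance that only a limit is reported.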

Compound 3, half-maximal inhibitory concentration: > 100000 nM
Compound 3 was reported as a limit (the forecaster's own chance of this, stated with the estimate: 55%); the middle value sits exactly at the limit.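

In this assay compound 3 gives > 100000 nM, which is a limit and not a number. Compound 2 and compound 3 both end in limits, so the step between them cannot be read, and the methyl on this aromatic carbon, para to a large group, adds no readable value to the series. The exchange of chloro for methyl reads as an at least 1.1-fold higher number from compound 1 to compound 3 (0.06 log units; that floor lies within the scatter), which leaves chloro as the only group at this position with a measured number and gives no ranking of the two groups, the series now resting largely on one end of the range: the limit of > 100000 nM in this assay, at which 2 of the 3 values shown sit.

Going by these compounds, how an amine or a carboxylic acid on this aromatic carbon would read in this assay stays open, as does whether any group there can give a number clearly lower than that of compound 1. Also open, on these data alone, is whether a change elsewhere on the shared core, away from this aromatic carbon, would bring the series into the readable range.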